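A few compounds are considered here, and "the series" means these few. Any claim that something is new, unique, unknown or untested is made for them only; others in the source may bear on it.

Compound 1 `CC(C)(C)C#Cc1cc(N(C(=O)[C@H]2CC[C@H](C)CC2)[C@H]2CC[C@H](Oc3ccc4nccn4n3)CC2)c(C(=O)O)s1` was tested in an ADME assay on MT4 cells (Homo sapiens) for cytotoxicity, with a stated time of 5 days (on this read-out higher numbers stand for lower toxicity in this test and lower numbers for higher toxicity in this test), and gave only a limit of the assay, > 20000 nM. Compound 2 `CC1CC=C(C(=O)N(c2cc(C#CC(C)(C)C)sc2C(=O)O)C(C)C)CC1` likewise gave only a limit, > 20000 nM. Compound 1 therefore stands at the limit of > 20000 nM in this assay, at which 2 of the 2 values shown sit, and no numbered value sets it apart. Compound 3 `CC(C)(C)C#Cc1cc(N(C(=O)[C@H]2CC[C@H](C)CC2)[C@H]2CC[C@H](O)CC2)c(C(=O)O)s1` differs from compound 1 by a hydrogen atom in place of a group of 9 heavy atoms (6 carbon, 3 nitrogen; one five-membered aromatic ring with 2 hetero atoms, one six-membered aromatic ring with 2 hetero atoms), on an oxygen on a saturated carbon. For the measured compounds named here, no measured pair shows this change, so the expected step from compound 1 to compound 3 is estimated as a step that the limit leaves unreadable from compound 1 to compound 3, within the scatter. Compound 3 is expected to give about 30000 nM, between 10000 nM and 100000 nM.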

Compound 3, half-maximal cytotoxic concentration: > 20000 nM
Compound 3 gave a limit, no number (the forecaster's own chance of this, stated with the estimate: 80%); the middle value is on the limit's open side.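

For the compounds shown here, compound 1 and compound 3 each give only a limit in this assay, and no step between them can be read. The compounds shown leave open where the half-maximal cytotoxic concentration of any of them actually lies.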